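The source may hold more compounds than are shown below. What is called first, only, known or untested is meant among the compounds shown, and "the series" means these compounds.

In a functional assay on BMDM cells (Mus musculus, strain C57BL/6) for inhibition, with a stated time of 2 days (a lower number here means a stronger inhibitor, a higher number a weaker inhibitor), three compounds have been measured. Compound 1 `CCOC(=O)c1sc(NC(=O)Cn2cc(-c3cccs3)nn2)nc1C` gives 20 nM, compound 2 `Cc1cc(NC(=O)Cn2cc(-c3ccc(Cl)cc3)nn2)no1` gives 1910 nM, and compound 3 `O=C(Cn1cc(-c2ccc([N+](=O)[O-])cc2)nn1)Nc1nccs1` gives 1040 nM. On these three numbers compound 2 stands highest; its nearest neighbour is compound 3, whose number lies within the scatter of that of compound 2, while compound 1 lies far below both, beyond the scatter. Compound 4 `Cc1cc(NC(=O)Cn2cc(-c3ccc(C#N)cc3)nn2)no1` has not yet been measured in this assay. It differs from compound 2 in one place: cyano in place of chloro on an aromatic carbon. The change sits on an aromatic carbon of a six-membered aromatic ring of carbon only, para to a large group. Among the measured compounds shown here, no step between measured compounds that differ in exactly one place is available, so nothing in the data shows how such an exchange has moved the numbers before. Compound 4 is therefore expected to land close to compound 2, with a step of a 1.0-fold higher number from compound 2 to compound 4 (0.02 log units; within the scatter) not beyond the scatter in either direction; the estimate for compound 4 in this assay is 2000 nM, with a range from 800 nM to 5000 nM.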

Compound 4, half-maximal inhibitory concentration: 9320 nM
For compound 4 the middle estimate is 4.7-fold (0.67 log units) below the measured one; the measured number lies above the stated range.
By their numbers in this assay, from the lowest: compound 1; then compounds 3 and 2 (each within the scatter of the next); then compound 4.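

In this assay, among the compounds shown here, cyano in place of chloro on an aromatic carbon, para to a large group, gives a 4.9-fold higher number from compound 2 to compound 4 (0.69 log units; beyond the scatter), the only step here that isolates a single place. It shows that inhibition at this position on the six-membered aromatic ring of carbon only is sensitive to the group it carries, as this exchange weakens inhibition beyond the scatter. Nothing available explains why this exchange has this effect.

On these data alone, whether the loss is specific to cyano, or whether other groups at this place, such as methoxy or an amine, would retain or improve on the inhibition of compound 2, remains open. Equally open, as far as these compounds go, is whether the same exchange would move the number in the same direction on a different core, such as that of compound 1.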